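The compounds below may be only part of what the source reports. "The series", "measured", "known", "first", "only" and "open" are said of these compounds alone.

Of the compounds shown here, two have been measured in a functional assay on U-937 cells (Homo sapiens) for cytotoxicity, read by MTT assay, with a stated time of 48 h; on this read-out higher numbers stand for weaker inhibition and lower numbers for stronger inhibition. Compound 1 `Fc1cccc(-c2nc(Nc3ccccc3)c3cc(F)ccc3n2)c1` carries a plain phenyl group on the ring nitrogen, and in this assay compound 1 gives 45500 nM. Compound 2 `Fc1cccc(-c2nc(Nc3ccccc3F)c3cc(F)ccc3n2)c1` adds a fluorine on that phenyl group; in this assay compound 2 reaches only the assay limit of > 50000 nM, so no exact number is known for it. The step of an at least 1.0-fold higher number from compound 1 to compound 2 (0.04 log units; that floor lies within the scatter) is therefore only a floor, and it lies within the scatter, so the two compounds cannot be told apart on these numbers. Compound 2 thus stands at the weak end of what this assay can report, as the evidence the limit of > 50000 nM in this assay, at which 1 of the 2 values shown sits, shows.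

Compound 3 `Fc1cccc(-c2nc(Nc3ccc(Br)cc3)c3cc(F)ccc3n2)c1` differs from compound 2 by 4-bromophenyl in place of 2-fluorophenyl on a nitrogen on an aromatic ring. Within the data shown here, no measured step involves a bromine or a change on that part of the ring; the only step known, from a plain phenyl to a fluorophenyl, produced no movement beyond the scatter. The change to compound 3 is therefore expected to leave the number near where compound 2 sits, with a step of an at least 1.1-fold lower number from compound 2 to compound 3 (0.04 log units; that floor lies within the scatter). Compound 3 is estimated at 45000 nM, in the range 20000 nM to 100000 nM.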

Compound 3, half-maximal inhibitory concentration: > 50000 nM
Compound 3 ended at the assay's limit; the forecaster's own chance of this, stated with the estimate: 50%; middle value at least 1.1-fold (0.04 log units) from the limit.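

With 4-bromophenyl on the nitrogen, compound 3 also stops at a limit rather than giving a number in this assay, so a second halogen-bearing phenyl group at this position gives no exact value, and the read-out stays at its weak end: the limit of > 50000 nM in this assay, at which 2 of the 3 values shown sit.

Against the plain phenyl group of compound 1, the one step that can be read is an at least 1.0-fold higher number from compound 1 to compound 3 (0.04 log units; that floor lies within the scatter), so this change gives only a floor and does not separate these two compounds. The step between compound 2 and compound 3 cannot be read, since both compounds sit at a limit and nothing shows how far apart they truly are.

From the compounds shown here alone, what stays open is whether any group on this phenyl ring, such as an amine, a methoxy group or a carboxylic acid, would give a clearly lower number than compound 1 at 45500 nM. Also open, going by these compounds, is whether replacing the phenyl group on the nitrogen with a longer alkyl chain would move the number at all.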